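Nitro-to-amino exchange on the benzylamine arm

The source may hold more compounds than are shown below. What is called first, only, known or untested is meant among the compounds shown, and "the series" means these compounds.

In an assay for inhibition of Indoleamine 2,3-dioxygenase 1 (Homo sapiens), with stated times of 10 min and 60 min, tested at 100 uM (on this read-out lower numbers stand for a weaker effect and higher numbers for a stronger effect at the one concentration tested), compound 1 `O=[N+]([O-])c1cccc(CNc2cc(Br)cc3[nH]ncc23)c1` gives 95%, and compound 2 `O=[N+]([O-])c1cccc(CNc2cc(C(F)(F)F)cc3[nH]ncc23)c1` gives 69%. Going by the values given here, the only measured step, a number 26 percentage points lower from compound 1 to compound 2 (beyond the scatter), concerns trifluoromethyl in place of bromo on an aromatic carbon of the shared core. Among the compounds with values here, compound 2 therefore stands lowest of the two numbers so far, with compound 1 the nearer and higher one. Compound 3 `Nc1cccc(CNc2cc(C(F)(F)F)cc3[nH]ncc23)c1` carries the change (amino in place of nitro on an aromatic carbon), on an aromatic carbon of a six-membered aromatic ring of carbon only. Within the data shown here, no measured step touches this group; the one step recorded concerns a different position and offers no guide to direction or size here. With nothing to anchor it, the expected step is a number 7 percentage points lower from compound 2 to compound 3 (within the scatter), not beyond the scatter, and the range is kept wide. For compound 3 the estimate in this assay is 62%, within 30% to 88%.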

Compound 3, a percentage reported as inhibition, at one concentration (the size of the read-out at that concentration, not a potency): 55%
Compound 3: the middle estimate sits 7 percentage points above what was measured; low and high end bracket the measured number.
By their numbers in this assay, from the lowest: compound 3; then compound 2; then compound 1.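

In this assay, amino in place of nitro gives a number 14 percentage points lower from compound 2 to compound 3 (beyond the scatter), the first step read at this aromatic carbon, meta to a large group; the earlier step concerned only the shared core. The position therefore responds to the group it carries, yet nitro is not needed for a measurable effect at the one concentration tested, as compound 3 still gives 55%. Nothing at hand accounts for the size or direction of this step.

Whether the same exchange also lowers the number on the bromo-bearing core of compound 1 stays open, as amino is shown only with trifluoromethyl on the core. Also open, from the compounds shown here alone, is how a nitrile, a carboxylic acid or an acetamide at this place would stand against nitro and amino.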